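Chloro for methyl on the shared core, compound 4

A few compounds are considered here, and "the series" means these few. Any claim that something is new, unique, unknown or untested is made for them only; others in the source may bear on it.

Compound 1 `Cc1nnc2sc(C(=O)NC3CN(c4ncc(C(F)(F)F)cn4)C3)c(N)c2c1C` gives 10.6 mL/min/kg in an ADME assay (Rattus norvegicus) for pharmacokinetics (a lower number here means slower removal, a higher number faster removal of the compound), the lowest of the three numbers in hand. Compound 3 `COc1cc(N2CC(NC(=O)c3sc4nnc(Cl)c(C)c4c3N)C2)c(Cl)cn1`, which carries a chloro on its core and a different substituted aryl on the azetidine, gives 15.3 mL/min/kg, a gap within the scatter of compound 1. Going by the values given here, compound 2 `Cc1c(CF)nnc2sc(C(=O)NC3CN(c4ncc(C(F)(F)F)cn4)C3)c(N)c12` gives 23.7 mL/min/kg; the step of a 2.2-fold higher number from compound 1 to compound 2 (0.35 log units; beyond the scatter) is the only one-place change in the set.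

Compound 4 `Cc1c(Cl)nnc2sc(C(=O)NC3CN(c4ncc(C(F)(F)F)cn4)C3)c(N)c12` is not yet measured. It differs from compound 1 by chloro in place of methyl on an aromatic carbon.

The bearing step is that to compound 2, which alters the same methyl group that compound 4 loses, and it gave a modest rise in the number. Compound 3 shows that a chloro on the core is compatible with a number within the scatter of compound 1, but it differs from compound 1 in more than one place, so its value is only context. The expectation for compound 4 is therefore a step of a 1.3-fold higher number from compound 1 to compound 4 (0.12 log units; within the scatter) in this assay, a small rise that may not exceed the scatter. Compound 4 is estimated at 14 mL/min/kg, with a range from 8 mL/min/kg to 25 mL/min/kg.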

Compound 4, clearance: 51.9 mL/min/kg
Beside the measured number, compound 4's estimate is 3.7-fold (0.57 log units) below it; measured number outside the range, above it.
By their numbers in this assay, from the lowest: compounds 1, 3 and 2 (each within the scatter of the next, the first and the last beyond it); then compound 4.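

Methyl, fluoromethyl and chloro have now been compared on the same aromatic carbon, next to the ring nitrogen, and this position proves sensitive in this assay: the exchange of methyl for chloro gives a 4.9-fold higher number from compound 1 to compound 4 (0.69 log units; beyond the scatter). Chloro also separates from fluoromethyl, with a 2.2-fold higher number from compound 2 to compound 4 (0.34 log units; beyond the scatter), so together with a 2.2-fold higher number from compound 1 to compound 2 (0.35 log units; beyond the scatter) the three groups form an order in which each step lies beyond the scatter, with methyl lowest and chloro highest. No supporting data on the origin of these steps are at hand, so the series records only their direction and size.

The compounds shown leave open where an ethyl chain, a nitrile or an amine on this aromatic carbon would fall in that order, and so whether the rise is specific to chloro or extends to other replacements of methyl. Going by these compounds, it also remains open whether the step from methyl to chloro carries over to the substituted aryl on the azetidine of compound 3, as the step is defined only with the trifluoromethyl-bearing aryl of compound 1.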